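Biaryl to phenylbutynyl on the shared core

The source may report more compounds than this note shows. Statements on the series, on what has been measured and on what is new or still open speak of the compounds shown alone.

Measured so far in a functional assay on NIH3T3 cells (Mus musculus); a higher number here means that more compound is needed for the effect, a lower number that less compound is needed:
compound 1, `Cn1cncc1C(OCc1ccc(C#N)cc1C#Cc1ccc(C#N)cc1)c1ccc(C#N)cc1`, gives 11.6 nM.
compound 2, `Cn1cncc1C(OCc1ccc(C#N)cc1C#CC1(O)CCCCC1)c1ccc(C#N)cc1`, gives 1.93 nM.
compound 3, `Cn1cncc1C(OCc1ccc(C#N)cc1-c1ccc(-c2ccccc2)cc1)c1ccc(C#N)cc1`, gives only a limit of the assay, < 0.1 nM.

From the compounds shown here alone, compound 3 therefore stands at the edge of what this assay reports (the limit of < 0.1 nM in this assay, at which 1 of the 3 values shown sits), and its true position is unknown. Compound 4, `Cn1cncc1C(OCc1ccc(C#N)cc1C#CCCc1ccccc1)c1ccc(C#N)cc1`, differs from compound 3 in one place: 4-phenylbut-1-yn-1-yl in place of 4-phenylphenyl on an aromatic carbon. Among the compounds with values here, the steps that bear on this are an at least 110-fold lower number from compound 1 to compound 3 (2.06 log units; beyond the scatter) and an at least 19-fold lower number from compound 2 to compound 3 (1.28 log units; beyond the scatter), both large and both moving from a triple-bonded group toward the 4-phenylphenyl. Compound 4 runs the other way, back to a triple bond, so the step of an at least 40-fold higher number from compound 3 to compound 4 (1.60 log units; beyond the scatter) is expected to raise the number. Compound 4 is expected to give 4 nM, within 0.5 nM to 30 nM.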

Compound 4, half-maximal effective concentration: 130 nM
Compound 4: the middle estimate sits 33-fold (1.51 log units) below what was measured; measured number above the stated range.
By their numbers in this assay, from the lowest: compound 2; then compound 1; then compound 4. At a limit, below all of these: compound 3.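

In this assay, what the triple-bonded carbon carries matters in its own right: phenethyl gives an 11-fold higher number from compound 1 to compound 4 (1.05 log units; beyond the scatter) and a 67-fold higher number from compound 2 to compound 4 (1.83 log units; beyond the scatter). A phenyl ring at the end of the group is not enough on its own at this position, as an at least 1300-fold higher number from compound 3 to compound 4 (3.11 log units; beyond the scatter) shows. That step is only a bound, as compound 3 sits at a limit: the limit of < 0.1 nM in this assay, at which 1 of the 4 values shown sits.

From the compounds shown here alone, it remains open whether the low number of compound 2 comes from its hydroxyl or from its cyclohexyl ring. Going by these compounds, it is also open whether an amine at the end of the chain would lower the number of compound 4.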